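The source may report more compounds than this note shows. Statements on the series, on what has been measured and on what is new or still open speak of the compounds shown alone.

Notes on the series. Compound 1 `C/C(=N\NC(=O)COc1cccc2ccccc12)c1ccc(C#N)cc1Br`, compound 2 `C/C(=N\NC(=O)COc1cccc2ccccc12)c1ccc(Cl)cc1` and compound 3 `C/C(=N\NC(=O)COc1cccc2ccccc12)c1ccc(O)cc1O` share one core and differ only in the aryl group on the carbon with a double bond to nitrogen. In an ADME assay on HEL cells (Homo sapiens) for cytotoxicity (a higher number here means that more compound is tolerated, a lower number that less compound is tolerated), compound 1 gives 20 ug/mL. For compound 2 the reading in this assay is a limit of the assay, >= 4 ug/mL, not a number. For compound 3 the reading in this assay is likewise a limit, > 100 ug/mL, and so compound 3 sits at the top of the values shown, one further value shown also being a limit. The step of an at least 5.0-fold higher number from compound 1 to compound 3 (0.69 log units; beyond the scatter) is the only one that can be read; a step that the limit leaves unreadable from compound 1 to compound 2 and a step that the two limits leave unreadable from compound 2 to compound 3 are left unreadable by the limits.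

Compound 4 `C/C(=N\NC(=O)COc1cccc2ccccc12)c1ccc(O)cc1` has not been measured. It differs from compound 3 in one place: hydrogen in place of hydroxy on an aromatic carbon. Going by the values given here, no measured step removes a single hydroxy from an aryl group that keeps another, so the bearing is indirect: an at least 5.0-fold higher number from compound 1 to compound 3 (0.69 log units; beyond the scatter) shows that compound 3 with its 2,4-dihydroxyphenyl is tolerated up to the limit, while compound 1 with a bromo and a nitrile on the same ring is tolerated less. Compound 4 keeps one hydroxy and carries no halogen, so a reading near compound 3 is expected, with a small drop at most, and an at least 1.4-fold lower number from compound 3 to compound 4 (0.15 log units; that floor lies within the scatter) is the expected step. The estimate for compound 4 in this assay is 70 ug/mL, within 25 ug/mL to 100 ug/mL, and a further limit reading is expected to be quite possible.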

Compound 4, minimum cytotoxic concentration: 20 ug/mL
Beside the measured number, compound 4's estimate is 3.5-fold (0.54 log units) above it; measured number below the stated range.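

In this assay, going by these compounds alone, the first change of a single hydroxy, on the aromatic carbon ortho to a large group and meta to a hydroxy group, gives an at least 5.0-fold lower number from compound 3 to compound 4 (0.69 log units; beyond the scatter) and shows that the high tolerated level of compound 3 does not carry over to the 4-hydroxyphenyl, which keeps only the other hydroxy. There is also no change at the digits printed from compound 1 to compound 4 (within the scatter) and so, in this pair, an aryl group with no bromo and no nitrile gives no reading apart from the 2-bromo-4-cyanophenyl, and the halogen-free ring alone does not bring the tolerance of compound 3. As far as these compounds go, the reading of compound 3 is a limit, so the drop on losing this hydroxy is a floor and its full size stays unknown: the limit of > 100 ug/mL in this assay, at which 1 of the 4 values shown sits.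

The step between compound 2 and compound 4 cannot be read, the reading of compound 2 being a limit: the limit of >= 4 ug/mL in this assay, at which 1 of the 4 values shown sits. From the compounds shown here alone, whether the tolerance depends on the hydroxy itself at the place ortho to a large group, or would also hold with another group there, stays open, and a methoxy, an amine or a carboxylic acid on that carbon would bear on this.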